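The source may report more compounds than this note shows. Statements on the series, on what has been measured and on what is new or still open speak of the compounds shown alone.

The study concerns three related compounds examined in a functional assay on A549 cells (Homo sapiens) for cytotoxicity; a lower number here means that less compound is needed, a higher number that more compound is needed for the effect. Compound 1, `CCCCCCCC#CC#C/C=C\C(C)=O`, reaches only a limit of that assay: in this assay compound 1 gives > 50 ug/mL, which is a limit and not a number. Compound 2, `C=CCCCCCCCC#CC#C/C=C/C(C)=O`, likewise reaches only a limit: in this assay compound 2 gives > 50 ug/mL. Among the measured compounds shown here, compound 2 therefore stands where every measured value so far stands, as both values shown sit at the same boundary (the limit of > 50 ug/mL in this assay, at which 2 of the 2 values shown sit). For the measured compounds named here, no step between measured compounds can be drawn, since compound 1 and compound 2 differ in more than one place.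

Compound 3, `CCCCCCCC#CC#C/C=C/C(C)=O`, is the next compound. It differs from compound 2 as follows: hydrogen in place of vinyl on a saturated chain carbon, seven bonds along the chain from a triple-bonded carbon. With the measured values of compound 1 and compound 2 both resting at the same limit, the data give no step size in this assay to build on, and the account expects no change beyond the usual scatter from this change. The expected step is a number no higher from compound 2 to compound 3 (the limit leaves the size open), essentially none. Compound 3 is estimated at 50 ug/mL, with a range from 20 ug/mL to 120 ug/mL, and most probably it too will be reported only as a limit.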

Compound 3, concentration for half-maximal effect: > 50 ug/mL
Compound 3 gave a limit, no number; the forecaster's own chance of this, stated with the estimate: 80%; the middle value lies on the limit itself.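

In this assay compound 3 gives > 50 ug/mL as a limit and not a number. The steps from compound 1 and from compound 2 to compound 3 therefore cannot be read: the limit of > 50 ug/mL in this assay, at which 3 of the 3 values shown sit. The compounds shown leave open how far any of the three lies from that limit, and whether the vinyl group or the double-bond configuration changes the value at all.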